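Shortening a chain on the aromatic nitrogen

The compounds below may be only part of what the source reports. "The series", "measured", "known", "first", "only" and "open" are said of these compounds alone.

Measured compounds:
compound 1 `CCc1ccccc1-n1nc(C)c2c1NC(=O)[C@H](C)S[C@@H]2c1ccc(Oc2ccccc2)cc1`: 190%
compound 2 `CCCc1ccccc1-n1nc(C)c2c1NC(=O)[C@H](C)S[C@@H]2c1ccc(Oc2ccccc2)cc1`: 240%
compound 3 `Cc1ccc(-n2nc(C)c3c2NC(=O)[C@H](C)S[C@@H]3c2ccc(Oc3ccccc3)cc2)cc1`: 11%

In an assay on isolated protein for agonist activity at Bile acid receptor (Homo sapiens), read by AlphaScreen, with a stated time of 30 min (a higher number here means a larger maximal response, a lower number a smaller maximal response), compound 2 gives 240%, the highest of the three numbers; compound 1 sits below it, and compound 3, carrying a 4-methylphenyl on the aromatic nitrogen, gives 11%, far below both. Compound 4 `Cc1ccccc1-n1nc(C)c2c1NC(=O)[C@H](C)S[C@@H]2c1ccc(Oc2ccccc2)cc1` differs from compound 2 in one spot: hydrogen in place of ethyl on a saturated chain carbon bound to an aromatic carbon. The step of a number 50 percentage points higher from compound 1 to compound 2 (beyond the scatter) bears on this most directly: adding one carbon to the chain went with a larger response, so taking two away is expected to go the other way, likely by more. The step of a number 229 percentage points lower from compound 2 to compound 3 (beyond the scatter) changes a different part and only shows how low such compounds can fall. For compound 4 a step of a number 110 percentage points lower from compound 2 to compound 4 (beyond the scatter) is expected, giving an estimate of 130%, range 70% to 190%.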

Compound 4, largest response reached (reported as efficacy), in percent of the reference or control that the assay uses: 118%
Estimate against measurement, compound 4: 12 percentage points above; the measured number falls inside the stated range.
By their numbers in this assay, from the lowest: compound 3; then compound 4; then compound 1; then compound 2.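

In this assay, the response now follows chain length across three members, methyl, ethyl and propyl: it is a number 72 percentage points lower from compound 1 to compound 4 (beyond the scatter) and a number 122 percentage points lower from compound 2 to compound 4 (beyond the scatter). Even so, 2-methylphenyl keeps far more response than 4-methylphenyl, a number 107 percentage points higher from compound 3 to compound 4 (beyond the scatter), so a change in where a single methyl sits on the ring separates these two compounds without any change in chain length. Nothing here gives a measured reason for either trend. As far as these compounds go, whether a butyl chain in place of propyl would extend the rise or end it remains open.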